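The source may hold more compounds than are shown below. What is called first, only, known or untested is meant among the compounds shown, and "the series" means these compounds.

Measured in a functional assay on HeLa cells (Homo sapiens) for inhibition, read by CCK-8 assay, with a stated time of 48 h; a lower number here means a stronger inhibitor, a higher number a weaker inhibitor:
- Compound 1 `Cc1ccc(C2=NN(C3=NC(c4ccccc4)CS3)C(c3ccc4ccccc4c3)C2)cc1`: 2460 nM
- Compound 2 `O=C1CSC(N2N=C(c3ccc(Cl)cc3)CC2c2cccc3ccccc23)=N1`: 8840 nM
- Compound 3 `Cc1ccc(C2=NN(C3=NC(c4ccccc4)CS3)C(c3cccc4ccccc34)C2)cc1`: 4290 nM

Compound 3, at 4290 nM, cannot be told apart from compound 1, at 2460 nM. Its value lies lower than that of compound 2, at 8840 nM, and that gap goes beyond the scatter.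

Compound 4 `Cc1ccc(C2=NN(C3=NC(=O)CS3)C(c3cccc4ccccc34)C2)cc1` keeps the naphthalen-1-yl group and the 4-methylphenyl group of compound 3, and the change is a group of 6 heavy atoms (3 carbon, 1 nitrogen, 1 oxygen, 1 sulfur; one five-membered non-aromatic ring with 2 hetero atoms) in place of a group of 11 heavy atoms (9 carbon, 1 nitrogen, 1 sulfur; one five-membered non-aromatic ring with 2 hetero atoms, one six-membered aromatic ring of carbon only), on an amine nitrogen in a ring. For the measured compounds named here, the only measured step, a 1.7-fold higher number from compound 1 to compound 3 (0.24 log units; within the scatter), exchanges naphthalen-1-yl for naphthalen-2-yl on a saturated ring carbon. It leaves the changing group untouched, so it gives no direct measure of the step at hand. Going by the values given here, the better guide is compound 2, at 8840 nM, the one measured compound that already carries the entering group, although it lacks the 4-methylphenyl group. With a single such compound, this remains a weak basis.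

In this assay, a modest move towards a higher number is therefore expected, close to the edge of the scatter. The expected change is a 2.1-fold higher number from compound 3 to compound 4 (0.32 log units; beyond the scatter), an estimate only. For compound 4 the estimated value is 9000 nM, with an expected range from 3800 nM to 20000 nM.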

Compound 4, half-maximal inhibitory concentration: 3210 nM
The estimate for compound 4 lay 2.8-fold (0.45 log units) above the measured number; measured number outside the range, below it.
By their numbers in this assay, from the lowest: compounds 1, 4 and 3 (each within the scatter of the next); then compound 2.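

Read in this assay, the exchange on the amine nitrogen in a ring gives a 1.3-fold lower number from compound 3 to compound 4 (0.13 log units; within the scatter), so in this pair the smaller group, which has a carbonyl and lacks the six-membered aromatic ring of carbon only, takes the place of the larger one with no change that can be told from the scatter. The step that does go beyond the scatter lies elsewhere, at the other end of the molecule: methyl in place of chloro on an aromatic carbon gives a 2.8-fold lower number from compound 2 to compound 4 (0.44 log units; beyond the scatter), and so among these compounds, with the naphthalen-1-yl group held fixed, this exchange counts for more than the one on the amine nitrogen, though the step remains modest. Nothing measured among these compounds explains either step.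

As far as these compounds go, each exchange rests on a single pair, so whether either one holds with the naphthalen-2-yl group of compound 1 stays open. Also open, from the compounds shown here alone, is what an amine or a carboxylic acid would do on the aromatic ring that carries the methyl in compound 4, since only methyl and chloro appear at that place.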